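Amine esters on a shared core: compound 3 to compound 4

The source may report more compounds than this note shows. Statements on the series, on what has been measured and on what is new or still open speak of the compounds shown alone.

Measured so far in an ADME assay on L6 cells (Rattus norvegicus) for cytotoxicity (a lower number here means a stronger inhibitor, a higher number a weaker inhibitor), with these values:
- compound 1 `CCN(CC)CC(=O)OC1CC2(N(C)C)CC(c3ccccc3)C1C(c1ccccc1)C2` gives 30100 nM
- compound 2 `CN(C)C12CC(OC(=O)CN3CCCC3)C(C(c3ccccc3)C1)C(c1ccccc1)C2` gives 32700 nM
- compound 3 `CN(C)C12CC(OC(=O)CCN3CCCCC3)C(C(c3ccccc3)C1)C(c1ccccc1)C2` gives 25800 nM

Compound 3 is not separated from the other two, since its value lies within the scatter of both and the three form a single level without any order. Among the compounds with values here, compound 4 `CN(C)C12CC(OC(=O)CN3CCC(O)CC3)C(C(c3ccccc3)C1)C(c1ccccc1)C2` keeps the shared core and carries 4-hydroxypiperidin-1-yl in place of (piperidin-1-yl)methyl on a saturated chain carbon bound to a carbonyl carbon as its only difference from compound 3.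

Within the data shown here, three measured steps bear on this, all at that same place. They are a 1.1-fold higher number from compound 1 to compound 2 (0.04 log units; within the scatter) and a 1.2-fold lower number from compound 1 to compound 3 (0.07 log units; within the scatter) and also a 1.3-fold lower number from compound 2 to compound 3 (0.10 log units; within the scatter) as the widest, and each stays within the scatter. Among the measured compounds shown here, no measured compound carries 4-hydroxypiperidin-1-yl, so that part of the change remains untested. Amine changes here have so far left this assay flat, as a 1.3-fold lower number from compound 2 to compound 3 (0.10 log units; within the scatter) shows, and no step beyond the scatter is expected in either direction.

The expected step is a 1.2-fold higher number from compound 3 to compound 4 (0.09 log units; within the scatter) and it is only an estimate. For compound 4 the estimated value is 32000 nM with an expected range from 16000 nM up to 62000 nM in this assay.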

Compound 4, half-maximal inhibitory concentration: 102000 nM
The estimate for compound 4 lay 3.2-fold (0.50 log units) below the measured number, and the stated range ends below it.
By their numbers in this assay, from the lowest: compounds 3, 1 and 2 (each within the scatter of the next); then compound 4.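

In this assay this place, on a saturated chain carbon bound to a carbonyl carbon, can move the number after all, with a 4.0-fold higher number from compound 3 to compound 4 (0.60 log units; beyond the scatter) and a 3.1-fold higher number from compound 2 to compound 4 (0.49 log units; beyond the scatter) and also a 3.4-fold higher number from compound 1 to compound 4 (0.53 log units; beyond the scatter) as the three steps, which leave compound 4 as the weakest of the four. The shorter link alone does not account for the step, since compound 1 and compound 2 share the link of compound 4 yet stay within the scatter of compound 3, so the difference lies with 4-hydroxypiperidin-1-yl as a whole rather than with the chain. No measurement at hand explains why this group behaves differently from diethylamino, pyrrolidin-1-yl and (piperidin-1-yl)methyl.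

Still open, as far as these compounds go, is whether the hydroxyl or the six-membered ring carries the step, which a plain piperidin-1-yl on this same chain carbon would separate, while 4-methoxypiperidin-1-yl or morpholin-4-yl would test whether the hydroxyl itself is needed. Also open, from the compounds shown here alone, is whether the step survives on the longer link, as 2-(4-hydroxypiperidin-1-yl)ethyl would show, and whether it holds in any read-out other than this one.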